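A few compounds are considered here, and "the series" means these few. Any claim that something is new, unique, unknown or untested is made for them only; others in the source may bear on it.

Measured so far in a functional assay on NCI-H1975 cells (Homo sapiens) for inhibition, read by MTT assay, with a stated time of 72 h; a higher number here means a weaker inhibitor, a lower number a stronger inhibitor:
- Compound 1 `Cc1csc(Sc2cc(C(F)(F)F)nc(SCc3ccc(C(F)(F)F)cc3)n2)n1`: 5840 nM
- Compound 2 `FC(F)(F)c1ccc(CSc2nc(SC3=NCCS3)cc(C(F)(F)F)n2)cc1`: 24200 nM

Compound 2 holds the higher of these two numbers, which makes it the weaker inhibitor so far. Compound 3 `FC(F)(F)c1ccc(CSc2nc(Sc3ncc(-c4ccncc4)s3)cc(C(F)(F)F)n2)cc1` differs from it in one place: a group of 11 heavy atoms (8 carbon, 2 nitrogen, 1 sulfur; one five-membered aromatic ring with 2 hetero atoms, one six-membered aromatic ring with 1 hetero atom) in place of a group of 5 heavy atoms (3 carbon, 1 nitrogen, 1 sulfur; one five-membered non-aromatic ring with 2 hetero atoms), on a sulfur. Among the measured compounds shown here, the only measured step that bears on this is a 4.1-fold higher number from compound 1 to compound 2 (0.62 log units; beyond the scatter), a modest one, which went with the loss of a five-membered aromatic ring with 2 hetero atoms. As far as these compounds go, the entering group brings such a ring back, so a step of similar size towards a lower number is expected in this assay, although its six-membered aromatic ring with 1 hetero atom is untested. The expected change is a 4.8-fold lower number from compound 2 to compound 3 (0.68 log units; beyond the scatter). The estimate for compound 3 is 5000 nM, within a range of 1500 nM to 18000 nM.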

Compound 3, half-maximal inhibitory concentration: 16700 nM
Compound 3: the middle estimate sits 3.3-fold (0.52 log units) below what was measured; the measured number falls inside the stated range.
By their numbers in this assay, from the lowest: compound 1; then compounds 3 and 2 (each within the scatter of the next).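

In this assay, the change shows a 1.4-fold lower number from compound 2 to compound 3 (0.16 log units; within the scatter), so a five-membered aromatic ring on this sulfur is not enough on its own to reach the number of compound 1. The swap of 4-methyl-1,3-thiazol-2-yl for 5-(pyridin-4-yl)-1,3-thiazol-2-yl gives a 2.9-fold higher number from compound 1 to compound 3 (0.46 log units; beyond the scatter), which shows that the group carried by the thiazole ring matters here. No measurement shown explains this difference.

As far as these compounds go, it remains open how an unsubstituted 1,3-thiazol-2-yl group would compare. A thiazole ring carrying a phenyl ring or an amine is also untested among these compounds.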